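A few compounds are considered here, and "the series" means these few. Any claim that something is new, unique, unknown or untested is made for them only; others in the source may bear on it.

Of the compounds shown here, three of one shared core have been measured in a functional assay (aorta) with Oryctolagus cuniculus as the target; a lower number here means tighter binding, a higher number weaker binding. Compound 1 `COc1cc(C(C)=O)ccc1OCCCN1CCC(C(c2ccc(F)c(F)c2)c2ccc(F)c(F)c2)CC1` gives 2.51 nM, compound 2 `COc1cc(C(C)=O)ccc1OCCCN1CCC(C(NC(C)=O)(c2ccc(F)cc2)c2ccc(F)cc2)CC1` gives 63.1 nM, and compound 3 `COc1cc(C#N)ccc1OCCCN1CCC(C(c2ccc(F)cc2)c2ccc(F)cc2)CC1` gives 2 nM, the lowest of the three numbers; compound 1 lies within the scatter of it, while compound 2 lies well beyond. Compound 4 `CN(CCCN1CCC(C(c2ccc(F)cc2)c2ccc(F)cc2)CC1)c1ccccc1` has not yet been measured. It differs from compound 3 in one place: methyl(phenyl)amino in place of 4-cyano-2-methoxyphenoxy on a saturated chain carbon, three bonds along the chain from an amine nitrogen in a ring. Within the data shown here, no directly comparable step is known, so the expectation rests on compound 3 alone. Since what enters is smaller than what leaves, in this assay the step is expected to be a 5.0-fold higher number from compound 3 to compound 4 (0.70 log units; beyond the scatter), a modest move towards weaker binding. Compound 4 is therefore estimated at 10 nM, with a likely range from 3 nM to 40 nM.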

Compound 4, dissociation constant: 2 nM
Estimate against measurement, compound 4: 5.0-fold (0.70 log units) above; the whole stated range lies above it.
By their numbers in this assay, from the lowest: compounds 3, 4 and 1 (each within the scatter of the next); then compound 2.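

In this assay, methyl(phenyl)amino in place of 4-cyano-2-methoxyphenoxy, on a saturated chain carbon, three bonds along the chain from an amine nitrogen in a ring, gives no change at the digits printed from compound 3 to compound 4 (within the scatter). The nitrile, the methoxy group and the ether oxygen of compound 3 can therefore all be lost here without a shift beyond the scatter. Nothing at hand bears on why this is so.

On these data alone, it remains open whether the phenyl ring at this place could give way to a cyclohexyl group, or the methyl on its nitrogen to an ethyl group.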